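Acetyl in place of ethyl: compound 1 to compound 4

The source may report more compounds than this note shows. Statements on the series, on what has been measured and on what is new or still open speak of the compounds shown alone.

Compound 1 `CCc1cc(C(C)=O)c(O)cc1OCCCCC#N` gives 92% in an assay on isolated protein for inhibition of leukotriene B4 receptor 1 (Homo sapiens), tested at 10 uM; a higher number here means more inhibition at the concentration tested (going by the name of the read-out), a lower number less inhibition. Among the compounds with values here, on the three numbers measured so far it stands second highest. Its nearest neighbour is compound 2 `CSCc1cc(C(C)=O)c(O)cc1OCCCCCCC#N`, which gives 97%, a difference that stays within the scatter. Furthest away is compound 3 `CC(=O)c1cc(CO)c(OCCCCCCC#N)cc1O`, which gives 40%, a gap beyond the scatter.

Compound 4 `CC(=O)c1cc(C(C)=O)c(OCCCCC#N)cc1O` has not been measured. It differs from compound 1 in one place: acetyl in place of ethyl on an aromatic carbon.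

Within the data shown here, the only measured step between one-place neighbours is a number 57 percentage points lower from compound 2 to compound 3 (beyond the scatter), a change of hydroxy in place of methylsulfanyl on a saturated chain carbon bound to an aromatic carbon. That change touches a different group at a different place than the acetyl-for-ethyl exchange, so it does not bear on the step from compound 1 to compound 4. Among the measured compounds shown here, no measured pair isolates an acetyl in place of an ethyl on an aromatic carbon of the shared core. For the measured compounds named here, with no direct precedent, the expectation for compound 4 is a step of a number 12 percentage points lower from compound 1 to compound 4 (beyond the scatter), a small decrease that may well lie within the scatter. Compound 4 is therefore estimated at 80%, with a range from 45% to 97% in this assay.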

Compound 4, a percentage reported as inhibition, at one concentration (the size of the read-out at that concentration, not a potency): 8%
The estimate for compound 4 lay 72 percentage points above the measured number; the measured number lies below the stated range.
By their numbers in this assay, from the lowest: compound 4; then compound 3; then compounds 1 and 2 (each within the scatter of the next).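

On the aromatic carbon ortho to a group of 7 heavy atoms and para to a hydroxy group, the read-out proves highly sensitive to the exact group: in this assay, acetyl in place of ethyl gives a step of a number 84 percentage points lower from compound 1 to compound 4 (beyond the scatter). Within the data shown here, this is the first measured exchange of these two groups on the shared core, and it shows that going from ethyl, with 2 heavy atoms, to acetyl, with 3 heavy atoms and 1 hydrogen-bond acceptor, is enough to leave compound 4 at 8%. Nothing available accounts for this loss, so the series records its size and not its origin.

The compounds shown leave open whether the loss follows the carbonyl itself or would also appear with other groups on this carbon, and a propyl or a 1-hydroxyethyl group would help separate those two readings. Among these compounds, also open is whether the step holds with a longer nitrile chain on the oxygen, since the exchange of ethyl for acetyl is seen here on only one chain length.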